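Swapping sulfonyl for sulfanyl in a growth inhibitor

The compounds below may be only part of what the source reports. "The series", "measured", "known", "first", "only" and "open" are said of these compounds alone.

Compound 1 `Cc1ccc(S(=O)(=O)/C(=C/c2ccc(O)c([N+](=O)[O-])c2)C(=O)c2ccc(Cl)cc2)cc1` gives 25000 nM
Compound 2 `Cc1ccc(S(=O)(=O)/C(=C/c2ccc(Cl)cc2)C(=O)c2ccc(Cl)cc2)cc1` gives 1000 nM

Compound 1 has the higher of the two numbers in a functional assay on DU-145 cells (Homo sapiens) for inhibition, read by trypan blue exclusion, with a stated time of 96 h (on this read-out lower numbers stand for stronger inhibition of growth and higher numbers for weaker inhibition of growth), and so shows the weaker growth inhibition. Compound 3 `Cc1ccc(S/C(=C/c2ccc(O)c([N+](=O)[O-])c2)C(=O)c2ccc(Cl)cc2)cc1` changes it in one place: (4-methylphenyl)sulfanyl in place of (4-methylphenyl)sulfonyl on a double-bonded chain carbon bound to a carbonyl carbon and a double-bonded chain carbon, with (4-methylphenyl)sulfanyl in place of (4-methylphenyl)sulfonyl on a double-bonded chain carbon bound to a carbonyl carbon and a double-bonded chain carbon. Going by the values given here, the only measured step, a 25-fold lower number from compound 1 to compound 2 (1.40 log units; beyond the scatter), is large but replaces the 4-hydroxy-3-nitrophenyl instead. Among the compounds with values here, no measured step touches the sulfur group, so no direction can be read, and no shift beyond the scatter is expected in this assay. The expected change is a 1.3-fold lower number from compound 1 to compound 3 (0.10 log units; within the scatter). For compound 3 the estimate is 20000 nM, expected between 6000 nM and 70000 nM.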

Compound 3, concentration for 50% growth inhibition: 10000 nM
Beside the measured number, compound 3's estimate is 2.0-fold (0.30 log units) above it; the range from low to high includes it.
By their numbers in this assay, from the lowest: compound 2; then compound 3; then compound 1.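

In this assay the sulfur group on the double-bonded chain carbon bound to a carbonyl carbon and a double-bonded chain carbon proves able to shift the result: (4-methylphenyl)sulfanyl in place of (4-methylphenyl)sulfonyl gives a 2.5-fold lower number from compound 1 to compound 3 (0.40 log units; beyond the scatter) and so a modest gain in growth inhibition. Until now, only the 4-hydroxy-3-nitrophenyl group had been seen to matter. No evidence here explains this gain. Still open, going by these compounds, is whether the same swap helps on compound 2, and how a (4-methylphenyl)sulfinyl group or an amine would fare at this carbon.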